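From 3-bromophenyl to 2,3-dichlorophenyl on a shared core

The source may hold more compounds than are shown below. What is called first, only, known or untested is meant among the compounds shown, and "the series" means these compounds.

Compound 1 `O=C(N/N=C/c1cccc(Br)c1)Nc1cc2c(Nc3ccc(F)c(Cl)c3)ncnc2cc1O[C@H]1CCOC1`: 12400 nM
Compound 2 `O=C(N/N=C/c1ccc([N+](=O)[O-])cc1)Nc1cc2c(Nc3ccc(F)c(Cl)c3)ncnc2cc1O[C@H]1CCOC1`: "not active" (no number reported)

The series is tested in a functional assay on MCF7 cells (Homo sapiens) for cytotoxicity, read by MTT assay, with a stated time of 72 h; a lower number here means a stronger inhibitor, a higher number a weaker inhibitor. Within the data shown here, only one number is available there: compound 1 gives 12400 nM, so it has no numerical neighbour against which to be ranked. Among the measured compounds shown here, compound 2 is reported as "not active" (no number reported), with no number attached, and no measured step therefore exists in this small set.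

Compound 3 `O=C(N/N=C/c1cccc(Cl)c1Cl)Nc1cc2c(Nc3ccc(F)c(Cl)c3)ncnc2cc1O[C@H]1CCOC1` keeps the shared core of compound 1 and carries 2,3-dichlorophenyl in place of 3-bromophenyl on a carbon with a double bond to nitrogen. For the measured compounds named here, both groups are halogen-bearing phenyl rings, and the data contain no measured step that would point to a direction. In this assay, therefore, no change beyond the usual scatter is expected, and the expectation rests on compound 1 at 12400 nM alone. The estimated move is a 1.1-fold lower number from compound 1 to compound 3 (0.05 log units; within the scatter). A report without a number, as for compound 2, remains possible.

For compound 3 the expected value is 11000 nM, with an estimated range from 4000 nM to 30000 nM.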

Compound 3, half-maximal inhibitory concentration: "not active" (no number reported)
Compound 3: no number reported, and the estimate cannot be compared.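

In this assay, among these compounds, compound 3, like compound 2, is reported as not active without a number, so no step from compound 1 to compound 3 can be read. Nothing in the data bears on this result. The compounds shown leave open how far compound 2 and compound 3 stand from compound 1 in this assay.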